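Replacing the ethoxycarbonyl group of compound 1

The compounds below may be only part of what the source reports. "The series", "measured", "known", "first", "only" and "open" are said of these compounds alone.

compound 1 `CCOC(=O)c1c(C)coc1-c1ccc2c(CC)cccc2c1OC`: 2.2 ug/mL
compound 2 `CCc1cccc2c(OC)c(-c3occ(C)c3C(=O)NC)ccc12`: > 10 ug/mL (a limit of the assay)

Among the measured compounds shown here, in a functional assay on DU-145 cells (Homo sapiens) for cytotoxicity, read by MTT assay, with a stated time of 72 h (a higher number here means that more compound is needed for the effect, a lower number that less compound is needed), compound 1 gives 2.2 ug/mL as the only true number so far. Compound 2 gives > 10 ug/mL and that is a limit, not a number, as the limit of > 10 ug/mL in this assay, at which 1 of the 2 values shown sits, shows. For the measured compounds named here, the one measured step is an at least 4.5-fold higher number from compound 1 to compound 2 (0.65 log units; beyond the scatter) and it alters the same ethoxycarbonyl group. Compound 3 `CCc1cccc2c(OC)c(-c3occ(C)c3COCC(F)(F)F)ccc12` changes that group differently: (2,2,2-trifluoroethoxy)methyl in place of ethoxycarbonyl on an aromatic carbon. Given that single step from compound 1 at this group, an at least 4.5-fold higher number from compound 1 to compound 2 (0.65 log units; beyond the scatter), a smaller rise is expected in this assay here, though on thin evidence. The expected step is a 2.3-fold higher number from compound 1 to compound 3 (0.36 log units; beyond the scatter) in size. For compound 3 the estimated value is 5 ug/mL, with a range from 1.5 ug/mL to 14 ug/mL.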

Compound 3, concentration for half-maximal effect: 5.7 ug/mL
Compound 3: middle estimate off by 1.1-fold (0.06 log units), on the low side, within the range that was stated.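

Replacing ethoxycarbonyl with (2,2,2-trifluoroethoxy)methyl, a group without a carbonyl, still leaves a measurable value at this position, with a 2.6-fold higher number from compound 1 to compound 3 (0.41 log units; beyond the scatter). Set against the methylcarbamoyl group, the change gives an at least 1.7-fold lower number from compound 2 to compound 3 (0.24 log units; that floor lies within the scatter), so no order between these two compounds can be claimed. The value of compound 2 is a limit and not a number: the limit of > 10 ug/mL in this assay, at which 1 of the 3 values shown sits.

Open, going by these compounds, is whether a simple methoxymethyl group, a carboxylic acid or an amine at this position would keep the number near that of compound 1. Whether the fluorine atoms matter also stays open, as the non-fluorinated ethoxymethyl group is not among the compounds shown.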